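This account rests on a few compounds, and the source may have more. Where it says the series, first, only, none or still open, it means among the compounds named here.

Measured so far in an ADME assay for permeability, using PAMPA, with a stated time of 30 min, at pH 7.4; on this read-out lower numbers stand for lower permeability and higher numbers for higher permeability:

Compound 1 `CC(C)CCc1ccc2c(NCCCNCc3ccco3)ccnc2c1`: 23 10^-6 cm/s
Compound 2 `COc1ccc(F)cc1CNCCCNc1ccnc2cc(CCC(C)C)ccc12`: 23 10^-6 cm/s

For the measured compounds named here, compound 1 stands level with compound 2 in this assay; the single step between them, no change at the digits printed from compound 1 to compound 2 (within the scatter), lies within the scatter and shows that swapping the aryl group on the amine side of the chain left the read-out where it was. Compound 3 `c1coc(CNCCCNc2ccnc3cc(C4CCCCC4)ccc23)c1` has not yet been measured. It differs from compound 1 at a different site: cyclohexyl in place of isopentyl on an aromatic carbon.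

Going by the values given here, no measured step touches that aromatic carbon, so the one step on record, from compound 1 to compound 2, bears on the new change only in a general way: it shows that a change of similar size elsewhere in the molecule did not move the number. On that basis the step of a 1.0-fold lower number from compound 1 to compound 3 (0.02 log units; within the scatter) is expected to be small, with no direction that can be read from the data beyond the scatter. Compound 3 is therefore estimated at 22 10^-6 cm/s in this assay, with a range from 12 10^-6 cm/s to 40 10^-6 cm/s.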

Compound 3, apparent permeability: 23 10^-6 cm/s
The estimate for compound 3 lay 1.0-fold (0.02 log units) below the measured number; the range from low to high includes it.
By their numbers in this assay, from the lowest: compounds 1, 2 and 3 (each within the scatter of the next).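

In this assay, the aromatic carbon that carries isopentyl in compound 1 now has a step of its own: cyclohexyl in place of isopentyl gave no change at the digits printed from compound 1 to compound 3 (within the scatter). Within this one comparison, the read-out therefore tolerated a group with one six-membered non-aromatic ring of carbon only in place of a group with no ring, a change at a different site from the one separating the first two compounds. No measurement here offers an explanation for this lack of movement in the read-out, and nothing independent bears on it.

For the compounds shown here, the comparison covers only two groups at this aromatic carbon, both made of carbon alone, with no hydrogen-bond donors or acceptors and no net charge, so it leaves open whether a basic amine, a carboxylic acid or a longer chain at the same place would hold the number at this level. It is also open whether cyclohexyl would behave in the same way alongside the 5-fluoro-2-methoxyphenyl group of compound 2, since no step among these compounds combines the two changes.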